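Swapping a fluoro for trifluoromethyl on the side-ring

The compounds below may be only part of what the source reports. "The series", "measured", "known", "first", "only" and "open" are said of these compounds alone.

Of the compounds shown here, two sharing one core have been measured in a functional assay on ileum for antagonist activity at histamine H1 receptor (Cavia porcellus); a higher number here means weaker binding, a lower number tighter binding. Compound 1 `N=C(NCCCc1c[nH]cn1)NCCC(c1ccc(C(F)(F)F)cc1)c1ccccn1` gives 282 nM, and compound 2 `N=C(NCCCc1c[nH]cn1)NCCC(c1cccc(F)c1)c1ccccn1` gives 158 nM. The step between them is a 1.8-fold lower number from compound 1 to compound 2 (0.25 log units; within the scatter), so on the numbers shown compound 2 has the lower value of the two, but that gap falls within the usual scatter and does not separate the two compounds.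

Compound 3 `N=C(NCCCc1c[nH]cn1)NCCC(c1cccc(C(F)(F)F)c1)c1ccccn1` is the next structure, and it differs from compound 2 only in this way: trifluoromethyl in place of fluoro on an aromatic carbon. Going by the values given here, the only measured step that bears on it is the one just described, a 1.8-fold lower number from compound 1 to compound 2 (0.25 log units; within the scatter), which moved the trifluoromethyl group as well as replacing it with fluoro and still stayed within the scatter. On that basis, compound 3 is expected to show no change beyond the scatter in this assay, a step of about a 1.3-fold higher number from compound 2 to compound 3 (0.10 log units; within the scatter) from compound 2. The estimate for compound 3 in this assay is therefore 200 nM, with a range from 100 nM to 450 nM.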

Compound 3, dissociation constant: 525 nM
Beside the measured number, compound 3's estimate is 2.6-fold (0.42 log units) below it; the whole stated range lies below it.
By their numbers in this assay, from the lowest: compounds 2, 1 and 3 (each within the scatter of the next, the first and the last beyond it).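

In this assay, going by these compounds alone, trifluoromethyl in place of fluoro on this aromatic carbon, meta to a large group, gives the first step to lie beyond the scatter (a 3.3-fold higher number from compound 2 to compound 3 (0.52 log units; beyond the scatter)), so the choice between these two groups does register here, if only modestly. The other new step, 3-(trifluoromethyl)phenyl in place of 4-(trifluoromethyl)phenyl (a 1.9-fold higher number from compound 1 to compound 3 (0.27 log units; within the scatter)), stays within the scatter, so these numbers do not separate the two placements of trifluoromethyl, and compound 1 cannot be told apart from either compound 2 or compound 3. Nothing available on these compounds accounts for the step from fluoro to trifluoromethyl.

Two points are left open: whether the value climbs steadily with the group at this place, which chloro, methyl or methoxy there would help to test, and whether an unsubstituted phenyl ring would sit nearer to compound 2 or to compound 3. Within the data shown here, it is also open whether fluoro elsewhere on the ring would match compound 2, since fluoro appears at only one place in these compounds.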